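Bromo in place of benzyloxy: working notes on the series

The source may report more compounds than this note shows. Statements on the series, on what has been measured and on what is new or still open speak of the compounds shown alone.

In a functional assay for inhibition, with Homo sapiens as the target (a higher number here means a weaker inhibitor, a lower number a stronger inhibitor), compound 1 (`COc1cc(OC)c(C(=O)/C=C/c2ccc3ccccc3c2)c(OC)c1`) gives 2150 nM, compound 2 (`COC(=O)c1ccc(/C=C/C(=O)c2c(OC)cc(OC)cc2OC)cc1`) gives 1930 nM and compound 3 (`O=C(/C=C/c1ccccc1)c1ccccc1OCc1ccccc1`) gives 2230 nM. Compound 3 stands within the scatter of both others, so the three values cannot be ranked. Compound 4 (`O=C(/C=C/c1ccccc1)c1ccccc1Br`) has bromo in place of benzyloxy on an aromatic carbon, ortho to a large group (bromo in place of benzyloxy on an aromatic carbon). For the measured compounds named here, no measured pair shows this change, so the expectation rests on compound 3 at 2230 nM and on the narrow spread of the series. The expected result is a 1.1-fold higher number from compound 3 to compound 4 (0.05 log units; within the scatter), with no step beyond the scatter and no firm direction. For compound 4 the estimated value is 2500 nM, with an expected range of 900 nM to 7000 nM.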

Compound 4, half-maximal inhibitory concentration: 1660 nM
For compound 4 the middle estimate is 1.5-fold (0.18 log units) above the measured one, and the stated range covers the measured number.
By their numbers in this assay, from the lowest: compounds 4, 2, 1 and 3 (each within the scatter of the next).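

In this assay, bromo in place of benzyloxy on this aromatic carbon, ortho to a large group, gives a 1.3-fold lower number from compound 3 to compound 4 (0.13 log units; within the scatter). For the compounds shown here, this is the first single-place comparison, and it shows that benzyloxy, aromatic ring included, can give way to the single bromine here without a step beyond the scatter. Nothing measured speaks to the reason for this result. Still open, going by these compounds, is whether an amine or a carboxylic acid on this aromatic carbon would produce a step beyond the scatter.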